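From thiophen-2-yl to ethynyl on a shared core

A few compounds are considered here, and "the series" means these few. Any claim that something is new, unique, unknown or untested is made for them only; others in the source may bear on it.

Compound 1 `Nc1nc(N)c2c(-c3cccs3)cn([C@@H]3O[C@H](CO)[C@@H](O)[C@H]3O)c2n1`: > 20000 nM, a limit
Compound 2 `COc1nc(N)nc2c1c(-c1cccs1)cn2[C@@H]1O[C@H](CO)[C@@H](O)[C@H]1O`: > 20000 nM, a limit

In a functional assay on HL-60 cells (Homo sapiens) for antiproliferative activity, read by XTT assay, with a stated time of 72 h (on this read-out lower numbers stand for stronger inhibition and higher numbers for weaker inhibition), compound 2 has no exact number, only the limit > 20000 nM. The evidence so far amounts to the limit of > 20000 nM in this assay, at which 2 of the 2 values shown sit. Going by the values given here, the one measured step, a step that the two limits leave unreadable from compound 1 to compound 2, has no readable size and concerns a different place on the core, so it offers no guide to the next change.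

Compound 3 `C#Cc1cn([C@@H]2O[C@H](CO)[C@@H](O)[C@H]2O)c2nc(N)nc(OC)c12` differs from compound 2 as follows: ethynyl in place of thiophen-2-yl on an aromatic carbon. Ethynyl stands in place of thiophen-2-yl on an aromatic carbon, two ring bonds from the ring nitrogen. Among the compounds with values here, no measured step tests this exchange, so any expectation is loose, and a second limit remains quite possible. The expected direction in this assay is toward stronger inhibition, with an estimated at least 3.3-fold lower number from compound 2 to compound 3 (0.52 log units; beyond the scatter). Compound 3 is expected at 6000 nM, within an estimated range of 500 nM to 20000 nM.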

Compound 3, half-maximal inhibitory concentration: > 20000 nM
Compound 3 ended at the assay's limit; the forecaster's own chance of this, stated with the estimate: 45%; at least 3.3-fold (0.52 log units) between middle value and limit.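

Compound 2 and compound 3 both stand at a limit in this assay, and the step between them, ethynyl in place of thiophen-2-yl, cannot be read. The compounds shown leave open whether any change on the shared core gives an exact value: the limit of > 20000 nM in this assay, at which 3 of the 3 values shown sit.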